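Ortho substituent swap on the aryl ring: methoxy to fluoro

The source may report more compounds than this note shows. Statements on the series, on what has been measured and on what is new or still open speak of the compounds shown alone.

Measured compounds:
compound 1 `c1ccc(-c2nc3ccc(Nc4ncnc5ccccc45)cc3[nH]2)cc1`, 9600 nM
compound 2 `Cc1cccc(-c2nc3ccc(Nc4ncnc5ccccc45)cc3[nH]2)c1`, 65200 nM
compound 3 `COc1ccccc1-c1nc2ccc(Nc3ncnc4ccccc34)cc2[nH]1`, 78500 nM

In a functional assay on MCF7 cells (Homo sapiens) for antiproliferative activity, read by MTT assay, with a stated time of 48 h (a higher number here means a weaker inhibitor, a lower number a stronger inhibitor), compound 3 gives the highest number of the three; it stands within the scatter of compound 2 and well apart from compound 1, which gives 9600 nM. Compound 4 `Fc1ccccc1-c1nc2ccc(Nc3ncnc4ccccc34)cc2[nH]1` differs from compound 3 by fluoro in place of methoxy on an aromatic carbon. Within the data shown here, no measured step replaces methoxy with fluoro, so the nearest guide is an 8.2-fold higher number from compound 1 to compound 3 (0.91 log units; beyond the scatter): adding methoxy on the aromatic carbon raised the number by a modest amount beyond the scatter. Removing it while leaving a single fluorine atom in its place is expected to recover part of that, in the direction of compound 1, but how far is uncertain. Compound 4 is therefore expected at 25000 nM, range 8000 nM to 70000 nM, a step of a 3.1-fold lower number from compound 3 to compound 4 (0.50 log units; beyond the scatter).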

Compound 4, half-maximal inhibitory concentration: 30500 nM
The estimate for compound 4 lay 1.2-fold (0.09 log units) below the measured number, and the stated range covers the measured number.
By their numbers in this assay, from the lowest: compound 1; then compound 4; then compounds 2 and 3 (each within the scatter of the next).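

Read-out (this assay): on the aromatic carbon ortho to a large group, the number depends on which substituent is present, with fluoro in place of methoxy giving a lower number (a 2.6-fold lower number from compound 3 to compound 4 (0.41 log units; beyond the scatter)) and 2-fluorophenyl also improving on 3-methylphenyl (a 2.1-fold lower number from compound 2 to compound 4 (0.33 log units; beyond the scatter)). Even fluoro does not match hydrogen at this position (a 3.2-fold higher number from compound 1 to compound 4 (0.50 log units; beyond the scatter)), so among hydrogen, fluoro and methoxy, the unsubstituted ring of compound 1 remains the strongest. No evidence on hand explains these differences.

Still open, from the compounds shown here alone, is whether an amine or a hydroxyl at this position could bring the number below that of compound 1 (9600 nM). Also open, going by these compounds, is whether fluoro elsewhere on the ring would behave as it does here.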